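A few compounds are considered here, and "the series" means these few. Any claim that something is new, unique, unknown or untested is made for them only; others in the source may bear on it.

Among the measured compounds shown here, the three compounds measured so far share one core and differ only in the benzyl group bound to sulfur. Compound 1 `O=[N+]([O-])c1ccc(CSc2nnc(-c3ccc4c(c3)OCCO4)n2-c2ccccc2)cc1` carries a 4-nitrophenyl there, compound 2 `Clc1ccccc1CSc1nnc(-c2ccc3c(c2)OCCO3)n1-c1ccccc1` a 2-chlorophenyl, and compound 3 `Fc1ccc(CSc2nnc(-c3ccc4c(c3)OCCO4)n2-c2ccccc2)cc1` a 4-fluorophenyl. In a functional assay on HepG2 cells (Homo sapiens) for antiproliferative activity, read by MTT assay, with a stated time of 24 h (a lower number here means a stronger inhibitor, a higher number a weaker inhibitor), compound 1 gives 13800 nM. In this assay compound 2 gives 970 nM, the lowest of the three numbers, and compound 3 gives 1020 nM. The step of a 14-fold lower number from compound 1 to compound 2 (1.15 log units; beyond the scatter) is large, as is a 14-fold lower number from compound 1 to compound 3 (1.13 log units; beyond the scatter), whereas a 1.1-fold higher number from compound 2 to compound 3 (0.02 log units; within the scatter) lies within the scatter, so compound 2 and compound 3 cannot be told apart on these numbers.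

Compound 4 `Brc1ccccc1CSc1nnc(-c2ccc3c(c2)OCCO3)n1-c1ccccc1` is not yet measured. Its change from compound 2 is bromo in place of chloro on an aromatic carbon. For the measured compounds named here, no measured step exchanges chloro for bromo. The closest comparison is a 1.1-fold higher number from compound 2 to compound 3 (0.02 log units; within the scatter), where one halogen-bearing benzyl replaced another and the step stayed within the scatter; the large steps from compound 1 concern the departure of nitro and say nothing about a swap of one halogen for another. One would therefore expect compound 4 to show a step in this assay of a 1.1-fold lower number from compound 2 to compound 4 (0.03 log units; within the scatter), that is, none beyond the scatter. The estimate for compound 4 in this assay is 900 nM, with a range from 400 nM to 2000 nM.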

Compound 4, half-maximal inhibitory concentration: 4730 nM
Beside the measured number, compound 4's estimate is 5.3-fold (0.72 log units) below it; measured number outside the range, above it.
By their numbers in this assay, from the lowest: compounds 2 and 3 (each within the scatter of the next); then compound 4; then compound 1.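

In this assay the two halogens at this place can be told apart: the swap of chloro for bromo, on an aromatic carbon ortho to a large group, gives a 4.9-fold higher number from compound 2 to compound 4 (0.69 log units; beyond the scatter) and so lies beyond the scatter, unlike the earlier exchange of one halogen-bearing benzyl for another. The halogen-bearing benzyl groups therefore do not read as one level, with compound 4 going against any such pattern, as a 4.6-fold higher number from compound 3 to compound 4 (0.67 log units; beyond the scatter) also shows. The 2-bromobenzyl group still keeps part of the gain seen on leaving the 4-nitrophenyl group, with a 2.9-fold lower number from compound 1 to compound 4 (0.47 log units; beyond the scatter) placing compound 4 in the middle of the series, and no measurement shown here accounts for the difference between chloro and bromo.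

As far as these compounds go, it remains open whether this step follows bromo itself or its place ortho to a large group. Also open, from the compounds shown here alone, is how an iodo, a methyl or an amine on that same aromatic carbon, or a longer chain carrying the 2-bromophenyl group, would read in this assay against these four compounds.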